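The compounds below may be only part of what the source reports. "The series", "measured", "known", "first", "only" and "open" are said of these compounds alone.

Among the compounds with values here, in a functional assay on SK-OV-3 cells (Homo sapiens) for antiproliferative activity, read by MTT assay, with a stated time of 72 h (on this read-out higher numbers stand for weaker inhibition and lower numbers for stronger inhibition), compound 1 `COc1ccc(NC(=O)CCc2cccc3c2B(O)OC3)cc1` gives 900 nM and holds the lower of the two numbers measured so far, which means the stronger inhibition. Within the data shown here, compound 2 `O=C(CCc1cccc2c1B(O)OC2)Nc1ccc([N+](=O)[O-])cc1` at 83000 nM is its only measured neighbour. Compound 3 `COc1ccc(NC(=O)CCc2cccc3c2B(O)OC3)cc1OC` keeps the core of compound 1 and alters one place: methoxy in place of hydrogen on an aromatic carbon describes methoxy in place of hydrogen on an aromatic carbon, ortho to a methoxy group and meta to a large group.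

Among the measured compounds shown here, only one measured step bears on this, and only loosely: a 92-fold higher number from compound 1 to compound 2 (1.96 log units; beyond the scatter) when a nitro group replaces the methoxy group. That large step shows that the number can move strongly with a change on this ring. However, it removes the methoxy group, whereas compound 3 keeps it and gains another, and no measured pair shows methoxy replacing hydrogen. No direction can therefore be drawn from the data, so little change beyond the scatter is expected in this assay. The expected step is a 1.1-fold higher number from compound 1 to compound 3 (0.05 log units; within the scatter) as a rough estimate. For compound 3 the estimate is 1000 nM within an expected range of 250 nM to 4000 nM for repeated measurements.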

Compound 3, half-maximal inhibitory concentration: > 100000 nM
Compound 3 ended at the assay's limit (the forecaster's own chance of this, stated with the estimate: 3%); at least 100-fold (2.00 log units) between middle value and limit.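

Placing a methoxy group on this aromatic carbon, ortho to a methoxy group and meta to a large group, gives an at least 110-fold higher number from compound 1 to compound 3 (2.04 log units; beyond the scatter) in this assay. Until now, the only measured shift came from replacing the methoxy group with nitro, which gives a 92-fold higher number from compound 1 to compound 2 (1.96 log units; beyond the scatter) and could have suggested that keeping the methoxy group was enough; compound 3 keeps that group, yet the stronger inhibition of compound 1 is not retained, so a single added methoxy group at this position can matter greatly. Compound 3 gives > 100000 nM and this is a limit of the assay, not a number, so the full size of the step stays unknown: the limit of > 100000 nM in this assay, at which 1 of the 3 values shown sits.

The compounds shown leave open whether this large step belongs to methoxy specifically or would also follow other groups at this place, such as a fluorine atom, a hydroxyl group or an amine. They also leave open whether a longer chain, such as ethoxy, would behave in the same way, and whether adding methoxy here would have the same result without the existing methoxy group.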